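A few compounds are considered here, and "the series" means these few. Any claim that something is new, unique, unknown or untested is made for them only; others in the source may bear on it.

Three compounds share one core and differ only in the group attached to the triple-bonded carbon. Compound 1 `C[C@@H](NC(=O)c1ccc(C#Cc2ccccc2)cn1)C(C)(C)O` carries a phenyl there; in a functional assay on HEK293 cells for positive allosteric modulation of metabotropic glutamate receptor 5 (Rattus norvegicus), read by fluorescence and calcium flux (a higher number here means a larger maximal response, a lower number a smaller maximal response), compound 1 reaches 60.9%. Compound 2 `Cc1cccc(C#Cc2ccc(C(=O)N[C@H](C)C(C)(C)O)nc2)c1` carries a 3-methylphenyl, and in this assay compound 2 reaches 68.6%, the highest of the three numbers shown, though its steps to the other two both lie within the scatter. Compound 3 `C[C@@H](NC(=O)c1ccc(C#CC2CC2)cn1)C(C)(C)O` carries a cyclopropyl, and in this assay compound 3 reaches 63.4%.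

Compound 4 `C[C@@H](NC(=O)c1ccc(C#Cc2cc(F)ccn2)cn1)C(C)(C)O` is not yet measured. It differs from compound 2 in one place: 4-fluoropyridin-2-yl in place of 3-methylphenyl on a triple-bonded carbon

Two measured steps change the same position. The step of a number 7.7 percentage points higher from compound 1 to compound 2 (within the scatter) and the step of a number 5.2 percentage points lower from compound 2 to compound 3 (within the scatter) both stay within the scatter, even where a phenyl is exchanged for a cyclopropyl. On that basis, a change to a 4-fluoropyridin-2-yl is expected to give no step beyond the scatter, with an expected step of a number 5.6 percentage points lower from compound 2 to compound 4 (within the scatter). For compound 4 in this assay the estimate is 63%, expected between 50% and 78%.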

Compound 4, largest response reached (reported as efficacy), in percent of the reference or control that the assay uses: 66.2%
Beside the measured number, compound 4's estimate is 3.2 percentage points below it, within the range that was stated.
By their numbers in this assay, from the lowest: compounds 1, 3, 4 and 2 (each within the scatter of the next).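

Swapping the carbon-only ring of 3-methylphenyl for 4-fluoropyridin-2-yl, which has a ring nitrogen and a fluorine and brings a hydrogen-bond acceptor, leaves the maximal response in this assay essentially unchanged: a number 2.4 percentage points lower from compound 2 to compound 4 (within the scatter). The other two comparisons, a number 2.8 percentage points higher from compound 3 to compound 4 (within the scatter) and a number 5.3 percentage points higher from compound 1 to compound 4 (within the scatter), also stay within the scatter, so among these four compounds an aromatic ring with a hetero atom sits on the triple-bonded carbon as readily as phenyl, 3-methylphenyl or cyclopropyl. Nothing available explains why the response changes so little across these groups.

Still open, from the compounds shown here alone, is whether the response holds for a different kind of group on this carbon, such as an amine, a carboxylic acid or a longer alkyl chain. A plain pyridin-2-yl would begin to separate the part played by the fluorine from that of the ring nitrogen.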